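A Methyl for a Fluoro on Compound 2

The source may report more compounds than this note shows. Statements on the series, on what has been measured and on what is new or still open speak of the compounds shown alone.

Within the data shown here, compound 2 `O=C(NC1CCN(Cc2ccc(OC3CCNCC3)c(Br)c2)CC1)c1cc2cc(F)ccc2s1` gives 53 nM in an assay on HEK293 cells for displacement of a labelled ligand from Urotensin-2 receptor (Homo sapiens), read by fluorescence, with a stated time of 90 min (on this read-out higher numbers stand for weaker inhibition and lower numbers for stronger inhibition), the lowest of the two numbers measured so far; its nearest neighbour, compound 1 `O=C(NC1CCN(Cc2ccc(OC3CCNCC3)c(Br)c2)CC1)c1cscn1`, gives 970 nM. Among the measured compounds shown here, the single measured step, an 18-fold lower number from compound 1 to compound 2 (1.26 log units; beyond the scatter), came with 5-fluoro-1-benzothiophen-2-yl in place of 1,3-thiazol-4-yl on a carbonyl carbon.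

Compound 3 `Cc1ccc2sc(C(=O)NC3CCN(Cc4ccc(OC5CCNCC5)c(Br)c4)CC3)cc2c1` is to be measured in this assay. It differs from compound 2 as follows: methyl in place of fluoro on an aromatic carbon. For the measured compounds named here, no measured step bears on this exchange: the only step known, from compound 1 to compound 2, swapped the whole group on the carbonyl carbon rather than a single substituent on it, and it was large. With nothing to point either way, compound 3 is expected to sit close to compound 2, with a step of a 1.1-fold lower number from compound 2 to compound 3 (0.03 log units; within the scatter) that need not go beyond the scatter. The estimate for compound 3 is 50 nM, within 20 nM to 130 nM.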

Compound 3, half-maximal inhibitory concentration: 74 nM
The estimate for compound 3 lay 1.5-fold (0.17 log units) below the measured number, and the stated range covers the measured number.
By their numbers in this assay, from the lowest: compounds 2 and 3 (each within the scatter of the next); then compound 1.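

In this assay, the exchange of fluoro for methyl on this aromatic carbon gives a 1.4-fold higher number from compound 2 to compound 3 (0.14 log units; within the scatter), so the two groups cannot be told apart at this position. The large step away from the 1,3-thiazol-4-yl group does not rest on the fluoro alone: a 13-fold lower number from compound 1 to compound 3 (1.12 log units; beyond the scatter) stands alongside an 18-fold lower number from compound 1 to compound 2 (1.26 log units; beyond the scatter), and both steps lie beyond the scatter. Nothing measured here accounts for this outcome.

Fluoro and methyl each count a single heavy atom with no hydrogen-bond donors or acceptors, so it remains open how this position would answer to an amine, a carboxylic acid or a longer chain. Also open, on these data alone, is whether hydrogen at this place would read the same as either group.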